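The source may hold more compounds than are shown below. What is called first, only, known or untested is meant among the compounds shown, and "the series" means these compounds.

Working notes on the series. Compound 2 `O=S(=O)(Nc1cccc(CO)c1)c1ccc(-c2ccc(Br)cc2)cc1` carries a bromo group on its outer ring and gives 2500 nM in a functional assay on J774 cells (Mus musculus) for cytotoxicity, read by resazurin assay, with a stated time of 72 h; a higher number here means a weaker inhibitor, a lower number a stronger inhibitor. Compound 3 `CN(C)c1ccc(-c2ccc(S(=O)(=O)Nc3cccc(CO)c3)cc2)cc1` differs in one place, and the step of an at least 2.0-fold higher number from compound 2 to compound 3 (0.30 log units; that floor lies within the scatter) carries only a floor. In this assay compound 3 gives only a limit, > 5000 nM, resting on (the limit of > 5000 nM in this assay, at which 1 of the 3 values shown sits). Compound 1 `O=S(=O)(Nc1cc(CO)ccc1O)c1ccc(-c2ccc(F)cc2F)cc1`, which carries the 2,4-difluorophenyl group on a different core, gives 200 nM in this assay. Going by these compounds, compound 4 `O=S(=O)(Nc1cccc(CO)c1)c1ccc(-c2ccc(F)cc2F)cc1` is untested; the change is 2,4-difluorophenyl in place of 4-(dimethylamino)phenyl on an aromatic carbon. Among the compounds with values here, the one measured step that bears on it, an at least 2.0-fold higher number from compound 2 to compound 3 (0.30 log units; that floor lies within the scatter), runs the other way, so a lower number is expected. Compound 4 is expected at 2000 nM, between 500 nM and 8000 nM. The expected step is an at least 2.5-fold lower number from compound 3 to compound 4 (0.39 log units; beyond the scatter).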

Compound 4, half-maximal inhibitory concentration: 300 nM
Compound 4: the middle estimate sits 6.7-fold (0.82 log units) above what was measured; measured number outside the range, below it.
By their numbers in this assay, from the lowest: compounds 1 and 4 (each within the scatter of the next); then compound 2. At a limit, above all of these: compound 3.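

At this position, on an aromatic carbon para to a large group, the 2,4-difluorophenyl group reads clearly lower than the 4-bromophenyl group in this assay, with an 8.3-fold lower number from compound 2 to compound 4 (0.92 log units; beyond the scatter). Against the 4-(dimethylamino)phenyl group the change gives an at least 16-fold lower number from compound 3 to compound 4 (1.22 log units; beyond the scatter), and that size is only a floor, resting on a limit: the limit of > 5000 nM in this assay, at which 1 of the 4 values shown sits. With the 2,4-difluorophenyl group held, hydrogen in place of hydroxy on the core gives a 1.5-fold higher number from compound 1 to compound 4 (0.18 log units; within the scatter).

The compounds shown leave open whether both fluorines are needed here, and how an unsubstituted phenyl or a carboxylic acid on the outer ring would read.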